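A Hydroxy Group Added to Two Flavonoid Cores

The source may report more compounds than this note shows. Statements on the series, on what has been measured and on what is new or still open speak of the compounds shown alone.

Compound 1 `COc1cc2c(cc1O)O[C@H](c1ccccc1)[C@@H](O)C2=O` and compound 2 `COc1c(O)cc2c(c1O)C(=O)[C@H](O)[C@@H](c1ccccc1)O2` share one core, while compound 3 `COc1ccc(-c2coc3cc(O)ccc3c2=O)c(O)c1` has another; the difference between the two cores is not broken down here. In a functional assay on cells (Mus musculus) for cytotoxicity, read by MTT assay, with a stated time of 72 h (on this read-out higher numbers stand for weaker inhibition and lower numbers for stronger inhibition), compound 1 reaches only a limit of the assay, > 100000 nM. Compound 2 likewise gives only a limit, > 100000 nM. The change hydroxy in place of hydrogen on an aromatic carbon therefore yields a step that the two limits leave unreadable from compound 1 to compound 2, a step that stays unreadable because of the limit of > 100000 nM in this assay, at which 2 of the 3 values shown sit. Compound 3 gives 49300 nM in this assay. Compound 4 `COc1ccc(-c2coc3cc(O)cc(O)c3c2=O)c(O)c1` carries the same kind of change, (hydroxy in place of hydrogen on an aromatic carbon); its surroundings differ in that the entering group is not ortho to a methoxy group. Because compound 3 gives 49300 nM and no readable step guides the change, an estimated step of a 1.2-fold lower number from compound 3 to compound 4 (0.09 log units; within the scatter) is expected. Compound 4 is thus estimated at 40000 nM, between 12000 nM and 130000 nM.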

Compound 4, half-maximal inhibitory concentration: 93600 nM
The estimate for compound 4 lay 2.3-fold (0.37 log units) below the measured number, and the stated range covers the measured number.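

On the core of compound 3, hydroxy in place of hydrogen on an aromatic carbon gives a 1.9-fold higher number from compound 3 to compound 4 (0.28 log units; within the scatter) in this assay, so on this core the change has no effect that can be told apart from scatter. Among these compounds, the same change on the core of compound 1 cannot be read, as the step between compound 1 and compound 2 is hidden: the limit of > 100000 nM in this assay, at which 2 of the 4 values shown sit. The series therefore does not show whether the change carries from one core to the other, only that the one readable step stays within the scatter.

From the compounds shown here alone, it remains open whether an amine or a carboxylic acid in place of the same hydrogen would give a step beyond the scatter on the core of compound 3. Going by these compounds, it also remains open how either group would behave on the core of compound 1.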